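A few compounds are considered here, and "the series" means these few. Any claim that something is new, unique, unknown or untested is made for them only; others in the source may bear on it.

Working notes on the series.

Two analogues on the shared core carry different aryl groups on the amide carbonyl. Compound 1 `Cc1ccc(C(=O)Nc2sc3c(c2C(N)=O)CCN(Cc2ccc(Cl)cc2Cl)C3)cc1` in a functional assay on HL-60 cells (Homo sapiens) for antiproliferative activity, with a stated time of 24 h (a higher number here means a weaker inhibitor, a lower number a stronger inhibitor), gives 19900 nM. Compound 2 `NC(=O)c1c(NC(=O)c2ccccc2F)sc2c1CCN(Cc1ccc(Cl)cc1Cl)C2` in this assay gives 13100 nM. For the measured compounds named here, the only measured step, a 1.5-fold lower number from compound 1 to compound 2 (0.18 log units; within the scatter), does not leave the scatter, so on the numbers so far compound 2 stands lowest of the two but is not separated from compound 1.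

Compound 3 `NC(=O)c1c(NC(=O)c2cccc([N+](=O)[O-])c2)sc2c1CCN(Cc1ccc(Cl)cc1Cl)C2` is not yet measured. Relative to compound 2 the change is 3-nitrophenyl in place of 2-fluorophenyl on a carbonyl carbon. Going by the values given here, the one step that bears on this place, a 1.5-fold lower number from compound 1 to compound 2 (0.18 log units; within the scatter), swapped one aryl group for another at the same carbonyl and moved the number by an amount within the scatter; no measured step tells what a nitro group on the phenyl does here. The expectation for compound 3 is therefore a step of a 1.1-fold higher number from compound 2 to compound 3 (0.06 log units; within the scatter) of no more than the scatter, with the direction open. Compound 3 is estimated at 15000 nM, with a range from 5000 nM to 45000 nM.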

Compound 3, half-maximal inhibitory concentration: 19800 nM
Estimate against measurement, compound 3: 1.3-fold (0.12 log units) below; the range from low to high includes it.
By their numbers in this assay, from the lowest: compounds 2, 3 and 1 (each within the scatter of the next).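

For the compounds shown here, the 3-nitrophenyl group is the first on this carbonyl carbon to bring hydrogen-bond acceptors, yet with it in place of 2-fluorophenyl this assay shows a 1.5-fold higher number from compound 2 to compound 3 (0.18 log units; within the scatter), and with it in place of 4-methylphenyl the same read-out shows a 1.0-fold lower number from compound 1 to compound 3 (0.00 log units; within the scatter). With 2-fluorophenyl, 4-methylphenyl and 3-nitrophenyl now compared at this one place, all three steps among these compounds stay within the scatter, so the added acceptors and the larger group come with no separable difference in this assay, and the three compounds cannot be put in any order. No separate measurement bears on this result.

From the compounds shown here alone, it remains open whether any group on this carbonyl carbon can move the number beyond the scatter, for example an amine or a carboxylic acid on the phenyl, or a longer chain in place of the phenyl. Every compound shown keeps the rest of the molecule unchanged, so whether the same lack of separation holds with a different group elsewhere on the shared core also stays undecided.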